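Dropping the cyclopropyl from the benzylic amine of compound 3

The source may report more compounds than this note shows. Statements on the series, on what has been measured and on what is new or still open speak of the compounds shown alone.

Compounds measured so far in an assay on isolated protein for inhibition of ubiquitin carboxyl-terminal hydrolase 7 (Homo sapiens), with stated times of 30 min and 2 h; on this read-out higher numbers stand for weaker inhibition and lower numbers for stronger inhibition:
compound 1 `Cn1nc2c(=O)n(CC3(O)CCN(Cc4ccc(-c5ccco5)cc4Cl)CC3)cnc2c1-c1ccc(C(F)(F)F)cc1` gives 530 nM
compound 2 `Cn1nc2c(=O)n(CC3(O)CCN(Cc4ccc(-c5ccc(C(=O)O)o5)cc4Cl)CC3)cnc2c1-c1ccc(CN)cc1` gives 753 nM
compound 3 `Cn1nc2c(=O)n(CC3(O)CCN(Cc4ccc(-c5ccco5)cc4Cl)CC3)cnc2c1-c1ccc(CNC2CC2)cc1` gives 54.1 nM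

Compound 3 holds the lowest number of the three in this assay; compound 1 stands nearest to it, compound 2 furthest, and both gaps are beyond the scatter. Among the measured compounds shown here, the one measured step that changes only one place, a 9.8-fold lower number from compound 1 to compound 3 (0.99 log units; beyond the scatter), shows that the group on the aryl ring attached to the shared core can move the number substantially.

Compound 4 `Cn1nc2c(=O)n(CC3(O)CCN(Cc4ccc(-c5ccco5)cc4Cl)CC3)cnc2c1-c1ccc(CN)cc1` is compound 3 with hydrogen in place of cyclopropyl on an amine nitrogen. For the measured compounds named here, no measured pair shows this change alone. Compound 2 also carries an aminomethyl group, but it differs from compound 4 at a second place as well, the carboxylic acid on the furan, so what its value shows cannot be separated into the two changes. The step from compound 1 to compound 3 bears on it only indirectly, by showing the sensitivity of this position.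

Compound 4 is therefore expected to give a higher number than compound 3 in this assay, by a step of roughly a 3.7-fold higher number from compound 3 to compound 4 (0.57 log units; beyond the scatter), though the direction is uncertain. The estimate for compound 4 is 200 nM, within a range from 60 nM to 700 nM.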

Compound 4, half-maximal inhibitory concentration: 18.1 nM
Beside the measured number, compound 4's estimate is 11-fold (1.04 log units) above it; measured number outside the range, below it.
By their numbers in this assay, from the lowest: compound 4; then compound 3; then compounds 1 and 2 (each within the scatter of the next).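

In this assay the cyclopropyl on the amine nitrogen turns out not to be needed, since removing it to leave the aminomethyl group lowers the number further (a 3.0-fold lower number from compound 3 to compound 4 (0.48 log units; beyond the scatter)). The gain seen when an amine-bearing group replaces trifluoromethyl on the aryl ring therefore does not depend on the cyclopropyl, and the plain aminomethyl group gives a large step of its own (a 29-fold lower number from compound 1 to compound 4 (1.47 log units; beyond the scatter)). Compound 4 also separates the two changes that compound 2 carried: with aminomethyl held constant, hydrogen in place of carboxy on the furan gives a large step (a 42-fold lower number from compound 2 to compound 4 (1.62 log units; beyond the scatter)), so the weak number of compound 2 goes with the carboxylic acid and not with the aminomethyl group.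

Nothing available here explains why these steps run as they do. On these data alone, it remains open whether a methyl or an ethyl on the amine nitrogen would stay close to compound 4 or fall back towards compound 3, how a longer aminoethyl chain would compare with aminomethyl, and whether a methyl ester or a primary amide on the furan would behave like the carboxylic acid.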